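This account rests on a few compounds, and the source may have more. Where it says the series, first, only, none or still open, it means among the compounds named here.

Compound 1 (`O=C([C@H](O)CS(=O)(=O)c1ccc2cc(Cl)ccc2c1)N1CCC(N2CCNC2=O)CC1`) gives 1.73 in a physicochemical assay for lipophilicity, measured as octanol-water partition, at pH 7.4 (on this read-out higher numbers stand for higher lipophilicity and lower numbers for lower lipophilicity), while compound 2 (`O=C([C@H](O)CS(=O)(=O)c1ccc2cc(Cl)ccc2c1)N1CCC(N2CCCC2=O)CC1`) gives 1.96 on the same scale. Compound 3 (`O=C([C@H](O)CS(=O)(=O)c1ccc2cc(Cl)ccc2c1)N1CCC(N2CCCS2(=O)=O)CC1`) gives 1.69 and so stands within the scatter of both. Compound 4 (`O=C([C@H](O)CS(=O)(=O)c1ccc2cc(Cl)ccc2c1)N1CCC(N2CCOCC2=O)CC1`) has 3-oxomorpholin-4-yl on that saturated ring carbon in place of the group carried by compound 3 (a group of 7 heavy atoms (4 carbon, 1 nitrogen, 2 oxygen; one six-membered non-aromatic ring with 2 hetero atoms) in place of a group of 7 heavy atoms (3 carbon, 1 nitrogen, 2 oxygen, 1 sulfur; one five-membered non-aromatic ring with 2 hetero atoms), on a saturated ring carbon). Three exchanges at this place bear on it: a number 0.23 log units higher from compound 1 to compound 2 (within the scatter) and a number 0.04 log units lower from compound 1 to compound 3 (within the scatter) and also a number 0.27 log units lower from compound 2 to compound 3 (within the scatter) all stay within the scatter. None of them brings in a six-membered ring, which leaves the guide indirect. On those steps, no change beyond the scatter is expected in this assay and the estimated step is small (a number 0.06 log units higher from compound 3 to compound 4 (within the scatter)). The estimate for compound 4 is 1.75 (expected range 1.4 to 2.1).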

Compound 4, distribution coefficient: 1.85
Compound 4: middle estimate off by 0.10 log units, on the low side; the range from low to high includes it.
By their numbers in this assay, from the lowest: compounds 3, 1, 4 and 2 (each within the scatter of the next).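

Moving to a six-membered ring at this saturated ring carbon brings no step that can be told from noise: in this assay 3-oxomorpholin-4-yl gives a number 0.16 log units higher from compound 3 to compound 4 (within the scatter) and a number 0.11 log units lower from compound 2 to compound 4 (within the scatter) and also a number 0.12 log units higher from compound 1 to compound 4 (within the scatter) when set against the three five-membered groups. Ring size thus joins the earlier exchanges as a change that leaves all four compounds within the scatter of one another. Nothing at hand gives a reason for this closeness. Still open, as far as these compounds go, is whether a primary amine or a carboxylic acid on this carbon would stay as close.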